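4-Fluoro-3-methylbenzyl on the amine nitrogen of compound 1

The source may hold more compounds than are shown below. What is called first, only, known or untested is meant among the compounds shown, and "the series" means these compounds.

Measured in a physicochemical assay for solubility, in phosphate buffer; on this read-out higher numbers stand for higher solubility and lower numbers for lower solubility (both values are limits):
compound 1 (`Cc1cc(N[C@H](CCCCN)C(=O)NO)cc(C)c1F`) gives > 5 ug/mL (a limit)
compound 2 (`Cc1cc(S(=O)(=O)NCCCC[C@@H](Nc2cc(C)c(F)c(C)c2)C(=O)NO)ccc1F`) gives > 5 ug/mL (a limit)

Compound 1 stands at a limit (> 5 ug/mL) and not at a number, so its place in this assay is known only as that limit. Compound 3 (`Cc1cc(CNCCCC[C@@H](Nc2cc(C)c(F)c(C)c2)C(=O)NO)ccc1F`) puts 4-fluoro-3-methylbenzyl in place of hydrogen on an amine nitrogen. For the measured compounds named here, no measured step gives a size for this change. Compound 2 also carries a group on that nitrogen and also reports a limit (> 5 ug/mL). On that reading, a step no larger than the usual scatter is expected, in no set direction (a step that the limit leaves unreadable from compound 1 to compound 3). Compound 3 is estimated at 8 ug/mL with an expected range from 3 ug/mL to 30 ug/mL in this assay and may well report only a limit.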

Compound 3, solubility: > 5 ug/mL
Compound 3 gave a limit, no number; the forecaster's own chance of this, stated with the estimate: 70%; the middle value does not contradict the limit.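

Compound 1 and compound 3 both report only a limit in this assay, so no step can be read between them: the limit of > 5 ug/mL in this assay, at which 3 of the 3 values shown sit.

The compounds shown leave open where the actual solubility of each compound lies, and whether 4-fluoro-3-methylbenzyl in place of hydrogen on the amine nitrogen changes it at all.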